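This account rests on a few compounds, and the source may have more. Where it says the series, first, only, none or still open, it means among the compounds named here.

Of the compounds shown here, three sharing one core have been tested so far in a functional assay on OVCAR-3 cells (Homo sapiens) for inhibition, read by sulforhodamine B assay, with a stated time of 48 h; a lower number here means a stronger inhibitor of growth, a higher number a weaker inhibitor of growth. In this assay, compound 1 `CCOC(=O)c1nn(-c2ccccc2)c(-c2ccc(Cl)cc2)c1CNC(C)(C)C` gives 134 nM; > 559000 nM (2 entries), several entries that do not agree with each other. Compound 2 `CCOC(=O)c1nn(-c2ccccc2)c(-c2ccc(Br)cc2)c1CNC(C)(C)C` shows the same mixed picture, with 2910 nM; > 509000 nM (2 entries), again several entries that do not agree. Compound 3 `CC(C)(C)NCc1c(C(=O)O)nn(-c2ccccc2)c1-c1ccc(Cl)cc1` stands at > 652000 nM, which is a limit of the assay and not a number. Its two further entries give no single number either, so compound 3 has no measured potency to build on, only a limit.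

The next compound, compound 4 `CC(C)(C)NCc1c(C(=O)O)nn(-c2ccccc2)c1-c1ccc(Br)cc1`, differs from compound 3 at one place: bromo in place of chloro on an aromatic carbon. Bromo takes the place of chloro on an aromatic carbon of a six-membered aromatic ring of carbon only, para to a large group, so that 4-chlorophenyl becomes 4-bromophenyl. Going by the values given here, no measured pair isolates this exchange, so the size of the step cannot be read from the data. No step beyond the usual scatter is expected, and the estimated change is an at least 1.1-fold lower number from compound 3 to compound 4 (0.05 log units; that floor lies within the scatter). Compound 4 will most likely also be reported only as a limit. For compound 4 the estimated value is 580000 nM, with an expected range from 100000 nM to 1000000 nM.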

Compound 4, concentration for 50% growth inhibition: > 585000 nM
Compound 4 ended at the assay's limit; the forecaster's own chance of this, stated with the estimate: 75%; middle value at least 1.0-fold (0.00 log units) from the limit.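

In this assay compound 4 stands at > 585000 nM, which is a limit of the assay and not a number. Going by these compounds alone, compound 3 also rests on a limit, > 652000 nM, so no step between compound 3 and compound 4 can be read. As far as these compounds go, whether 4-bromophenyl and 4-chlorophenyl differ at all here stays open, as do the disagreeing entries of compound 1 and compound 2.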